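Dropping the fluoropyridyl ring: permeability of compound 4

This account rests on a few compounds, and the source may have more. Where it says the series, first, only, none or still open, it means among the compounds named here.

The measured compounds:
Compound 1, `CCCCc1nc(=O)c(S(=O)(=O)c2ccc(-c3ccc(F)cc3)cc2)c(O)n1-c1c(OC)cccc1OC`, 132 nm/s
Compound 2, `CCCCc1nc(=O)c(S(=O)(=O)c2ccc(-c3ccc(F)nc3)cc2)c(O)n1-c1c(OC)cccc1OC`, 24 nm/s
Compound 3, `COc1cccc(OC)c1-n1c(COC(C)C)nc(=O)c(S(=O)(=O)c2ccc(-c3ccc(F)nc3)cc2)c1O`, 4 nm/s

In an ADME assay for permeability, using PAMPA, at pH 7.4 (a lower number here means that the compound crosses the layer more slowly, a higher number that the compound crosses the layer faster), compound 2 gives 24 nm/s, the second highest of the three numbers; compound 1 lies a 5.5-fold lower number from compound 1 to compound 2 (0.74 log units; beyond the scatter) away, and compound 3 lies a 6.0-fold lower number from compound 2 to compound 3 (0.78 log units; beyond the scatter) away. Compound 4, `CCCCc1nc(=O)c(S(=O)(=O)c2ccccc2)c(O)n1-c1c(OC)cccc1OC`, differs from compound 2 by hydrogen in place of 6-fluoropyridin-3-yl on an aromatic carbon. For the measured compounds named here, no measured step removes this group outright; the nearest guide is the step of a 5.5-fold lower number from compound 1 to compound 2 (0.74 log units; beyond the scatter), which shows that exchanging the carbon-only ring for the 6-fluoropyridin-3-yl lowered the number. Removing the 6-fluoropyridin-3-yl is therefore expected to move the number back upward, by a modest step of a 3.8-fold higher number from compound 2 to compound 4 (0.57 log units; beyond the scatter). Compound 4 is estimated at 90 nm/s, with a range from 30 nm/s to 250 nm/s.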

Compound 4, apparent permeability: 1.5 nm/s
Beside the measured number, compound 4's estimate is 60-fold (1.78 log units) above it; the measured number lies below the stated range.
By their numbers in this assay, from the lowest: compound 4; then compound 3; then compound 2; then compound 1.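

In this assay, hydrogen in place of the ring gives a 16-fold lower number from compound 2 to compound 4 (1.20 log units; beyond the scatter), and the same exchange against the 4-fluorophenyl gives an 88-fold lower number from compound 1 to compound 4 (1.94 log units; beyond the scatter). The earlier drop on moving to the 6-fluoropyridin-3-yl therefore did not mean that a ring at this aromatic carbon, para to a large group, lowers the number: both ringed compounds stand above hydrogen. No measurement shown accounts for this.

Going by these compounds, whether a single methyl or a saturated piperidine ring here would hold the number up stays open, as does whether hydrogen would act alike alongside the isopropoxy chain of compound 3.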